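Fluorophenyl for pyrimidinyl: from compound 1 to compound 4

The compounds below may be only part of what the source reports. "The series", "measured", "known", "first", "only" and "open" are said of these compounds alone.

Compound 1 `Cc1nn(-c2nc(-c3ccc(Cl)c(Cl)c3)c(SC(C)C)s2)c(C(=O)O)c1-c1cncnc1` is measured in a functional assay on BJAB cells (Homo sapiens) for antiproliferative activity, with a stated time of 4 days (a higher number here means that more compound is needed for the effect, a lower number that less compound is needed), and gives 22000 nM. Among the two compounds that return a number, compound 1 stands highest. Compound 2 `Cc1c(-c2cc(Cl)cc(Cl)c2)c(C(=O)O)nn1-c1nc(-c2cc(Cl)ccc2F)c(SC(C)C)s1` gives 4800 nM in this assay, a lower number than compound 1 by a gap that lies beyond the scatter. Compound 3 `Cc1c(-c2cc(Cl)cc(Cl)c2)c(C(=O)O)nn1-c1nc(-c2cnn(C)c2)c(SC(C)C)s1` is reported as "not active" (no number reported) in this assay, without a number. Among the compounds with values here, compound 2 and compound 3 differ from compound 1 in more than one place, so no single step between measured compounds is available here.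

Compound 4 `Cc1nn(-c2nc(-c3ccc(Cl)c(Cl)c3)c(SC(C)C)s2)c(C(=O)O)c1-c1cccc(F)c1` is not yet measured. It differs from compound 1 in one place: 3-fluorophenyl in place of pyrimidin-5-yl on an aromatic carbon. Within the data shown here, no measured pair shows this change, so the size of the step can only be expected, not read off. Given that compound 1 sits at the high end with 22000 nM, a step in this assay from compound 1 to compound 4 of a 2.8-fold lower number from compound 1 to compound 4 (0.44 log units; beyond the scatter) is expected, toward a lower number, of a size that may reach beyond the scatter but is not guaranteed to. The value of compound 4 in this assay is estimated at 8000 nM, within a range of 2500 nM to 25000 nM.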

Compound 4, half-maximal effective concentration: 900 nM
Compound 4: middle estimate off by 8.9-fold (0.95 log units), on the high side; the whole stated range lies above it.
By their numbers in this assay, from the lowest: compound 4; then compound 2; then compound 1.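

Within the data shown here, on an aromatic carbon of a five-membered aromatic ring with 2 nitrogen, next to the ring atom that bears a carboxy group, 3-fluorophenyl in place of pyrimidin-5-yl gives a 24-fold lower number from compound 1 to compound 4 (1.39 log units; beyond the scatter) in this assay, the first single-place step. The group at this position therefore has a large effect on the read-out, which compounds 1, 2 and 3 could not show because they differ from one another in more than one place. The change replaces a ring with 2 hetero atoms and 2 hydrogen-bond acceptors with a ring of carbon only that carries fluorine, but no available measurement bears on why the number drops.

Among these compounds, the single step does not separate the loss of the ring nitrogens from the gain of the fluorine, a question that plain phenyl, pyridin-3-yl or 3-aminophenyl at this carbon would address. It also leaves open whether the same exchange gives a step of similar size when the 3,4-dichlorophenyl group of the core is replaced by another aryl group.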